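The source may hold more compounds than are shown below. What is called first, only, known or untested is meant among the compounds shown, and "the series" means these compounds.

Working notes on the thioether series. Three compounds carry the same core and differ only in the group on the saturated chain carbon bound to sulfur. Compound 1 `C#CCSc1nnc(-c2cc(OC)c(OC)c(OC)c2)n1N1C(=O)c2ccccc2C1=O` bears an ethynyl there; in a functional assay on MKN-45 cells (Homo sapiens) for cytotoxicity, read by MTT assay, with a stated time of 48 h (on this read-out higher numbers stand for weaker inhibition and lower numbers for stronger inhibition), compound 1 gives > 200000 nM, which is a limit of the assay and not a number. Compound 2 `COc1cc(-c2nnc(SCc3ccccc3)n2N2C(=O)c3ccccc3C2=O)cc(OC)c1OC` bears a phenyl there; in this assay compound 2 gives > 200000 nM, again a limit. Compound 3 `COc1cc(-c2nnc(SCC(=O)c3ccc(Br)cc3)n2N2C(=O)c3ccccc3C2=O)cc(OC)c1OC` carries the ((4-bromophenyl)carbonyl)methyl chain, and in this assay compound 3 gives 22300 nM, the only real number among the three shown. The steps of an at least 8.9-fold lower number from compound 1 to compound 3 (0.95 log units; beyond the scatter) and an at least 8.9-fold lower number from compound 2 to compound 3 (0.95 log units; beyond the scatter) are read against the limit of > 200000 nM in this assay, at which 2 of the 3 values shown sit, and show the arylcarbonylmethyl chain as the only one that brings the read-out into the measurable range. The step that the two limits leave unreadable from compound 1 to compound 2 cannot be read.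

Compound 4 `COc1cc(-c2nnc(SCC(=O)c3ccc(F)c(F)c3)n2N2C(=O)c3ccccc3C2=O)cc(OC)c1OC` keeps that chain and changes only the aryl on the carbonyl carbon: 3,4-difluorophenyl in place of 4-bromophenyl on a carbonyl carbon. No measured step touches the aryl on the carbonyl, so nothing shown speaks for a change beyond the scatter. Compound 4 is therefore expected to sit near compound 3, with an expected step of a 1.3-fold higher number from compound 3 to compound 4 (0.13 log units; within the scatter). The estimate for compound 4 is 30000 nM, expected between 8000 nM and 150000 nM.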

Compound 4, half-maximal inhibitory concentration: > 200000 nM
Compound 4 ended at the assay's limit; the forecaster's own chance of this, stated with the estimate: 25%; middle value at least 6.6-fold (0.82 log units) from the limit.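

Until now only the group on the saturated chain carbon bound to sulfur had been seen to move the read-out; the aryl on the carbonyl carbon also counts in this assay, with 3,4-difluorophenyl in place of 4-bromophenyl giving a clear loss (an at least 8.9-fold higher number from compound 3 to compound 4 (0.95 log units; beyond the scatter)). In this assay compound 4 gives > 200000 nM, a limit of the assay and not a number, so the arylcarbonylmethyl chain alone does not guarantee a measurable value. The step above gives only a minimum size, and the steps from compound 1 and from compound 2 to compound 4 cannot be read, all of them resting on the same limit: the limit of > 200000 nM in this assay, at which 3 of the 4 values shown sit.

Among the compounds shown here, compound 3 remains the only measured value, and the two aryls differ both in their halogen and in where it sits, so these two effects cannot be separated. From the compounds shown here alone, whether 4-chlorophenyl, 4-fluorophenyl, 4-methoxyphenyl or unsubstituted phenyl on the carbonyl carbon would keep the read-out in the measurable range stays open, as does the outcome for an amine or a carboxylic acid on that ring.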